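The source may hold more compounds than are shown below. What is called first, only, known or untested is meant among the compounds shown, and "the series" means these compounds.

Measured so far in an assay for binding affinity to dual specificity mitogen-activated protein kinase kinase 4 (Homo sapiens), read by KINOMEscan, tested at 100 nM; on this read-out lower numbers stand for a stronger effect and higher numbers for a weaker effect at the one concentration tested:
compound 1, `CCCS(=O)(=O)Nc1ccc(F)c(C(=O)c2n[nH]c3ncc(-c4ccc(F)cc4)cc23)c1F`: 2.1%
compound 2, `CCCS(=O)(=O)Nc1ccc(F)c(C(=O)c2n[nH]c3ncc(-c4ccccc4C)cc23)c1F`: 7%
compound 3, `CCCS(=O)(=O)Nc1ccc(F)c(C(=O)c2n[nH]c3ncc(-c4ccc(C)cc4)cc23)c1F`: 5.4%

All three share one core and differ only in the aryl group on the pyrazolopyridine-free part of the scaffold as drawn; the assay numbers are low and close together. Compound 2 is the reference for the step considered here. Its number sits within the scatter of the two neighbours: a number 4.9 percentage points higher from compound 1 to compound 2 (within the scatter) and a number 1.6 percentage points lower from compound 2 to compound 3 (within the scatter). The remaining measured step, a number 3.3 percentage points higher from compound 1 to compound 3 (within the scatter), is likewise within the scatter, so the three measured changes of the aryl group give no step beyond it.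

Compound 4, `CCCS(=O)(=O)Nc1ccc(F)c(C(=O)c2n[nH]c3ncc(-c4ccc(N)cc4)cc23)c1F`, is not yet measured. Its difference from compound 2 is 4-aminophenyl in place of 2-methylphenyl on an aromatic carbon. Among the measured compounds shown here, none of the measured steps brings in an aminophenyl group, so the bearing of the measured steps is indirect: they show only that exchanging one aryl group for another at this position has so far moved this assay by less than the scatter. On that basis no step beyond the scatter is expected in this assay. For compound 4 the value in this assay is estimated at 6%, with a range of 1% to 20%. The step this estimate means is a number 1 percentage points lower from compound 2 to compound 4 (within the scatter), expected to stay within the scatter.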

Compound 4, a percentage reported as activity, at one concentration (the size of the read-out at that concentration, not a potency): 0.1%
For compound 4 the middle estimate is 5.9 percentage points above the measured one; the whole stated range lies above it.
By their numbers in this assay, from the lowest: compounds 4, 1, 3 and 2 (each within the scatter of the next).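

In this assay, 4-aminophenyl, which brings 1 hydrogen-bond donor and 1 hydrogen-bond acceptor where 2-methylphenyl has neither, leaves the read-out within the scatter of all three earlier aryl groups: a number 6.9 percentage points lower from compound 2 to compound 4 (within the scatter) and a number 5.3 percentage points lower from compound 3 to compound 4 (within the scatter) and a number 2 percentage points lower from compound 1 to compound 4 (within the scatter). The position, on an aromatic carbon of the fused system, therefore accepts a nitrogen-bearing substituent on the phenyl ring as well as the fluoro and methyl seen before, and the direct exchanges at the 4-position of the phenyl ring, amino for methyl and amino for fluoro, give no step beyond the scatter in this assay. Nothing available explains why these values stay so close, and none of the changes can be tied to a cause.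

Going by these compounds, whether an acetamide, a dimethylamino group, a carboxylic acid or a morpholine on this phenyl ring would also stay within the scatter remains open, as does the effect of an amino group at the 2-position of the ring. Each compound is read at one concentration only, so any difference in potency among these four remains unresolved.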